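A few compounds are considered here, and "the series" means these few. Any claim that something is new, unique, unknown or untested is made for them only; others in the source may bear on it.

Compound 1 `O=C(Nc1ccc(Oc2ccnc3[nH]ccc23)c(F)c1)c1cc2cccnc2n(-c2ccc(Br)cc2)c1=O` is the stronger of the two measured compounds: in a functional assay on A549 cells (Homo sapiens) for antiproliferative activity, read by MTT assay, with a stated time of 72 h (a higher number here means a weaker inhibitor, a lower number a stronger inhibitor), compound 1 gives 210 nM. Among the compounds with values here, its only measured neighbour, compound 2 `O=C(Nc1ccc(Oc2ccnc3[nH]ccc23)c(F)c1)c1cc2cccnc2n(-c2ccc(Br)cc2F)c1=O`, carries a fluoro in place of hydrogen on an aromatic carbon, and in this assay compound 2 gives 460 nM. That single measured step is a 2.2-fold higher number from compound 1 to compound 2 (0.34 log units; beyond the scatter), a modest weakening. Compound 3 `Cn1ccc2c(Oc3ccc(NC(=O)c4cc5cccnc5n(-c5ccc(Br)cc5)c4=O)cc3F)ccnc21` differs from compound 1 in a different place: methyl in place of hydrogen on an aromatic nitrogen. Within the data shown here, no measured step touches that nitrogen, so the change from compound 1 to compound 2 offers only a general hint, namely that one small added group somewhere on this shared core moved the number by a modest amount, and it cannot be carried over directly to the new site. With only that to go on, the step from compound 1 to compound 3 is expected to be small, a 1.7-fold higher number from compound 1 to compound 3 (0.22 log units; within the scatter), and it may well fall within the scatter. Compound 3 is therefore estimated at 350 nM in this assay. The likely range for compound 3 is expected to run from 130 nM to 1000 nM.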

Compound 3, half-maximal inhibitory concentration: 390 nM
Compound 3: middle estimate off by 1.1-fold (0.05 log units), on the low side; measured number inside the range.
By their numbers in this assay, from the lowest: compounds 1, 3 and 2 (each within the scatter of the next, the first and the last beyond it).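

In this assay, methyl in place of hydrogen on an aromatic nitrogen gives a 1.9-fold higher number from compound 1 to compound 3 (0.27 log units; within the scatter), so this change cannot be told apart from the ordinary variation between repeated measurements. Within the data shown here, this is the first reading at this nitrogen, which belongs to a five-membered aromatic ring with 1 nitrogen, whereas the earlier step concerned an aromatic carbon. It shows that the core of compound 1 does not need the hydrogen on this nitrogen to keep antiproliferative activity of this order, though nothing measured here explains why this swap is tolerated.

On these data alone, a single methyl is a small probe, so it remains open whether this nitrogen would accept an ethyl, a longer chain, or a chain ending in an amine or a carboxylic acid. It also remains open whether methyl on this nitrogen would give a similar result when combined with the fluoro of compound 2, since the two changes appear together in none of the compounds shown.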